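This account rests on a few compounds, and the source may have more. Where it says the series, first, only, none or still open, it means among the compounds named here.

Compound 1 `O=C(Nc1ccccc1C(F)(F)F)c1cc(Cl)ccc1O`: 19000 nM
Compound 2 `O=C(Nc1ccc(C(F)(F)F)cc1)c1cc(Cl)ccc1O`: 2800 nM
Compound 3 `O=C(Nc1ccc(C(F)(F)F)cc1Cl)c1cc(Cl)ccc1O`: 2400 nM

All three were tested in an ADME assay on cells (Macrophage, Mus musculus) for cytotoxicity, read by resazurin assay, with a stated time of 3 days; on this read-out lower numbers stand for stronger inhibition and higher numbers for weaker inhibition. Compound 1 gives the highest number of the three, while compound 2 and compound 3 give numbers close to one another. Compound 1 and compound 2 are built from the same atoms joined differently, and the difference between the two cores is not broken down here. Going from compound 2 to compound 3 the change is chloro in place of hydrogen on an aromatic carbon, and it moved the number by a 1.2-fold lower number from compound 2 to compound 3 (0.07 log units; within the scatter). Compound 4 `O=C(Nc1c(Cl)cccc1C(F)(F)F)c1cc(Cl)ccc1O` has not yet been measured; it arises from compound 1 by chloro in place of hydrogen on an aromatic carbon, the same change at the same kind of place. Because the earlier step was a 1.2-fold lower number from compound 2 to compound 3 (0.07 log units; within the scatter), the step from compound 1 to compound 4 in this assay is expected to be of similar size, about a 1.2-fold lower number from compound 1 to compound 4 (0.07 log units; within the scatter). Compound 4 is therefore estimated at 16000 nM, likely between 6000 nM and 40000 nM.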

Compound 4, half-maximal inhibitory concentration: 23000 nM
Beside the measured number, compound 4's estimate is 1.4-fold (0.16 log units) below it, and the stated range covers the measured number.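

In this assay, chloro in place of hydrogen on an aromatic carbon gave a 1.2-fold higher number from compound 1 to compound 4 (0.08 log units; within the scatter) and so no readable step on the core of compound 1. Set beside the same change on the other core, the two steps do not differ: the same change on two cores in this assay, a 1.2-fold lower number (0.07 log units; within the scatter) from compound 2 to compound 3 and a 1.2-fold higher number (0.08 log units; within the scatter) from compound 1 to compound 4, 1.4-fold (0.15 log units) apart, within the scatter of two such steps. Among the compounds shown here, this shows that the change stayed too small to read on both cores, but with only two small steps it does not show how a larger step would carry over, or what would happen on any further core.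

The compounds shown leave open whether another group in this place, such as an amine or a carboxylic acid, would give a step beyond the scatter.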